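The compounds below may be only part of what the source reports. "The series", "measured", "known", "first", "only" and "open" are said of these compounds alone.

Of the compounds shown here, three sharing one core have been measured in a functional assay on the whole organism (strain C57B/6) with Mus musculus as the target, in the maximal electroshock model; on this read-out lower numbers stand for an effect already at smaller amounts and higher numbers for an effect only at larger amounts of compound. Compound 1 `CCc1nncn1-c1ccc(OCc2ccc(F)cc2)cc1` gives 22.8 mg/kg, compound 2 `CCc1nncn1-c1ccc(OCc2cccc(Cl)c2)cc1` gives 27.4 mg/kg, and compound 3 `CCc1nncn1-c1ccc(OCc2c(Cl)cccc2Cl)cc1` gives 15.8 mg/kg. Compound 2 thus stands at the upper edge of the three numbers, yet its gap to compound 1 and its gap to compound 3 both fall within the scatter, so the three are not told apart in this assay. Among the measured compounds shown here, the only single-place step among them, a 1.2-fold higher number from compound 1 to compound 2 (0.08 log units; within the scatter), stays within the scatter as well.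

Compound 4 `CCCCCCOc1ccc(-n2cnnc2CC)cc1` is the unmeasured member. It differs from compound 2 in one place: pentyl in place of 3-chlorophenyl on a saturated chain carbon bound to an oxygen on an aromatic ring. For the measured compounds named here, no measured step exchanges an aromatic ring for a chain, so the one step in hand, from 4-fluorophenyl to 3-chlorophenyl, bears on it only loosely, and that step showed no movement beyond the scatter. With nothing pointing in either direction, the expected step is a 1.1-fold higher number from compound 2 to compound 4 (0.04 log units; within the scatter), and the range is widened because this kind of change has not been tested in this assay. Compound 4 is therefore estimated at 30 mg/kg, with a range from 12 mg/kg to 75 mg/kg.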

Compound 4, dose for half-maximal effect: 13.2 mg/kg
Beside the measured number, compound 4's estimate is 2.3-fold (0.36 log units) above it; the range from low to high includes it.
By their numbers in this assay, from the lowest: compounds 4, 3, 1 and 2 (each within the scatter of the next, the first and the last beyond it).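

Among the compounds shown here, at this position, on a saturated chain carbon bound to an oxygen on an aromatic ring, the result shows that an aromatic ring is not required for an effect in this assay: pentyl, which has no ring, replaces 3-chlorophenyl and gives the only step that lies beyond the scatter, a modest one (a 2.1-fold lower number from compound 2 to compound 4 (0.32 log units; beyond the scatter)). The same exchange made against 4-fluorophenyl stays within the scatter (a 1.7-fold lower number from compound 1 to compound 4 (0.24 log units; within the scatter)), so pentyl is set apart from 3-chlorophenyl but not from 4-fluorophenyl, and this is no general advantage of the chain over every ring-bearing group. No measurement at hand accounts for the step from 3-chlorophenyl to pentyl.

The compounds shown leave open whether the length of the chain matters at this position, since a shorter chain such as propyl or a longer one such as heptyl would be needed to tell. They also leave open how a branched chain, or a pentyl chain carrying an amine or a carboxylic acid, would behave in this assay at this place.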